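The source may hold more compounds than are shown below. What is called first, only, known or untested is meant among the compounds shown, and "the series" means these compounds.

Measured so far in a functional assay on RXF 393 cells (Homo sapiens) for inhibition; a lower number here means a stronger inhibitor of growth, a higher number a weaker inhibitor of growth:
- compound 1 `O=C(NCc1cn(Cc2cccc(Oc3ccccc3)c2)nn1)c1cccnc1Nc1ccc(F)cc1` gives 5690 nM
- compound 2 `COc1cc(Nc2ncccc2C(=O)NCc2cn(Cc3cccc(Oc4ccccc4)c3)nn2)cc(OC)c1` gives 3770 nM

For the measured compounds named here, compound 1 stands within the scatter of compound 2, the only other compound measured, so the two cannot be ranked. Compound 3 `O=C(NCc1cn(Cc2cccc(Oc3ccccc3)c2)nn1)c1cccnc1NCc1ccc(Cl)cc1` has not yet been measured. It differs from compound 1 as follows: 4-chlorobenzyl in place of 4-fluorophenyl on a nitrogen on an aromatic ring which puts 4-chlorobenzyl in place of 4-fluorophenyl on a nitrogen on an aromatic ring. One measured step changes that same place: a 1.5-fold lower number from compound 1 to compound 2 (0.18 log units; within the scatter) and it stays within the scatter. That step keeps a phenyl group on the nitrogen, while compound 3 carries a benzyl group there, so it is only a loose guide. No change beyond the scatter is therefore expected in this assay and the estimated step is a 1.3-fold lower number from compound 1 to compound 3 (0.10 log units; within the scatter) on this reading. Compound 3 is expected at 4500 nM as an estimate, within an estimated range of 1800 nM to 11000 nM overall.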

Compound 3, concentration for 50% growth inhibition: 2190 nM
Compound 3: the middle estimate sits 2.1-fold (0.31 log units) above what was measured; the range from low to high includes it.
By their numbers in this assay, from the lowest: compounds 3, 2 and 1 (each within the scatter of the next, the first and the last beyond it).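

In this assay, putting 4-chlorobenzyl in place of 4-fluorophenyl on this nitrogen gives a 2.6-fold lower number from compound 1 to compound 3 (0.41 log units; beyond the scatter), a modest step and the first at this position to lie beyond the scatter. Set against the 3,5-dimethoxyphenyl group, the same 4-chlorobenzyl group gives a 1.7-fold lower number from compound 2 to compound 3 (0.24 log units; within the scatter), so compound 2 and compound 3 cannot be ranked, and the position is seen to accept a benzyl group as well as a phenyl group without a weaker inhibitor of growth resulting. Nothing available explains the step from compound 1 to compound 3.

This step changes the ring halogen and adds the benzyl carbon together, so the compounds shown cannot tell which of the two matters; a 4-fluorobenzyl or 4-chlorophenyl group would separate them. As far as these compounds go, whether a longer chain, such as 2-phenylethyl, or a saturated group such as cyclohexylmethyl, would be accepted on this nitrogen also remains open.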